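The compounds below may be only part of what the source reports. "The series", "measured", "known", "first", "only" and "open" are said of these compounds alone.

Measured so far in an ADME assay on MT4 cells (Homo sapiens) for cytotoxicity, read by MTT assay (on this read-out higher numbers stand for lower toxicity in this test and lower numbers for higher toxicity in this test), each reading being a limit of the assay and not a number:

- Compound 1 `Cc1ccc(CNC(=O)C2C(=O)N(O)C(=O)c3ccccc32)cc1`: > 125000 nM
- Compound 2 `O=C(NCc1ccc(O)cc1O)C1C(=O)N(O)C(=O)c2ccccc21`: > 125000 nM

Compound 2 therefore has no numerical position in this assay. Its reading of > 125000 nM is a limit. The whole of the measured record comes down to the limit of > 125000 nM in this assay, at which 2 of the 2 values shown sit.

The next compound, compound 3 `O=C(NCc1ccc(O)c(O)c1)C1C(=O)N(O)C(=O)c2ccccc21`, has the same atoms as compound 2, joined differently. The change is 3,4-dihydroxyphenyl in place of 2,4-dihydroxyphenyl on a saturated chain carbon bound to an amide-type nitrogen, with 3,4-dihydroxyphenyl in place of 2,4-dihydroxyphenyl on a saturated chain carbon bound to an amide-type nitrogen.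

Among the compounds with values here, only one measured step bears on this change, and it concerns the same place on the molecule. That step, a step that the two limits leave unreadable from compound 1 to compound 2, offers no size to carry over, so no shift beyond the scatter is expected in this assay, in either direction. The data cannot rule out a real drop, so the expected range is kept wide on the lower side, and another limit is quite possible.

The expected change is an at least 1.2-fold lower number from compound 2 to compound 3 (0.09 log units; that floor lies within the scatter). For compound 3 the estimate is 100000 nM, with an expected range from 30000 nM to 125000 nM.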

Compound 3, half-maximal cytotoxic concentration: 11000 nM
Compound 3: middle estimate off by 9.1-fold (0.96 log units), on the high side; measured number outside the range, below it.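

Placing 3,4-dihydroxyphenyl in place of 2,4-dihydroxyphenyl on a saturated chain carbon bound to an amide-type nitrogen gives an at least 11-fold lower number from compound 2 to compound 3 (1.05 log units; beyond the scatter) in this assay. Within the data shown here, this shows that this place can affect the read-out even when the atoms stay the same and only their arrangement differs, something the unreadable step between the two limit values of the earlier compounds could not show. Compared with the 4-methylphenyl group, the 3,4-dihydroxyphenyl group gives an at least 11-fold lower number from compound 1 to compound 3 (1.05 log units; beyond the scatter), so compound 3 reads as more toxic in this test than either earlier compound, and both steps give only a minimum size, since each starts from a limit: the limit of > 125000 nM in this assay, at which 2 of the 3 values shown sit.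

The compounds shown leave open whether both hydroxyl groups of the 3,4-dihydroxyphenyl group are needed for this lower number, which a phenyl group carrying a single hydroxyl group or methoxy groups in their place would address. They also leave open whether the same drop would hold with a longer chain between the amide-type nitrogen and the ring.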